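Methyl to Chloro on Compound 2: What to Expect

The compounds below may be only part of what the source reports. "The series", "measured", "known", "first", "only" and "open" are said of these compounds alone.

Compound 2 `Cc1ccc(C2=NN(c3nc(-c4ccccc4)cs3)C(c3ccc(F)cc3)C2)s1` in a functional assay on A549 cells (Homo sapiens) for antiproliferative activity, read by XTT assay, with a stated time of 24 h (a lower number here means a stronger inhibitor, a higher number a weaker inhibitor), gives only a limit, > 500 ug/mL. Compound 1 `Cc1ccc(-c2csc(N3N=C(c4ccc(C)s4)CC3c3ccc(F)cc3)n2)cc1` likewise reaches only the limit > 500 ug/mL. Compound 3 `Cc1ccc(C2=NN(c3nc(-c4ccc(S(C)(=O)=O)cc4)cs3)C(c3ccc(F)cc3)C2)s1` too shows only the limit > 500 ug/mL. So compound 2 stands level with the other two, all resting at the limit of > 500 ug/mL in this assay, at which 3 of the 3 values shown sit. Compound 4 `Fc1ccc(C2CC(c3ccc(Cl)s3)=NN2c2nc(-c3ccccc3)cs2)cc1` differs from compound 2 in one place: chloro in place of methyl on an aromatic carbon. The measured steps that bear on it are a step that the two limits leave unreadable from compound 1 to compound 2, a step that the two limits leave unreadable from compound 1 to compound 3 and a step that the two limits leave unreadable from compound 2 to compound 3; none of them yields a readable size. For the step from compound 2 to compound 4 no direction can therefore be read, and compound 4 is expected most likely to remain at the limit as well, with a step that the limit leaves unreadable from compound 2 to compound 4 as the estimated step. The estimate for compound 4 in this assay is 700 ug/mL, within 200 ug/mL to 3000 ug/mL.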

Compound 4, half-maximal inhibitory concentration: > 500 ug/mL
Compound 4 ended at the assay's limit (the forecaster's own chance of this, stated with the estimate: 85%); the middle value is on the limit's open side.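

No new step can be read from compound 2 to compound 4, since both give a limit and not a number: the limit of > 500 ug/mL in this assay, at which 4 of the 4 values shown sit. The compounds shown leave open what size of effect, if any, chloro in place of methyl has in this assay.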